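This account rests on a few compounds, and the source may have more. Where it says the series, first, only, none or still open, it means among the compounds named here.

Two compounds built on a shared core have so far been examined in a functional assay on HEK293 cells for agonist activity at 5-hydroxytryptamine receptor 7 (Homo sapiens), read by cAMP accumulation, with a stated time of 30 min; on this read-out lower numbers stand for smaller maximal responses and higher numbers for larger maximal responses. Compound 1, `CCCN(CCC)Cc1ccc(Cl)c(-c2ccccc2OC)c1`, was reported in this assay as "not active" (no number reported), so no number is available for it. Within the data shown here, compound 2, `COc1ccccc1-c1cc(C2CCNC2)ccc1Cl`, is the only compound with a measured number: in this assay compound 2 reaches 29%, a modest maximal response compared with the reference. Compound 3, `COc1ccccc1-c1cc(C2CCN(C)C2)ccc1Cl`, has not yet been measured. It differs from compound 2 by methyl in place of hydrogen on an amine nitrogen in a ring. Among the measured compounds shown here, no step between two measured compounds is available, so the effect of this change cannot be read from a similar earlier pair. For the measured compounds named here, the only other compound, compound 1, gave no measurable response, which cautions against expecting a rise. Compound 3 is therefore expected to give 20%, with a likely range from 0% to 45%. The expected step of a number 9 percentage points lower from compound 2 to compound 3 (within the scatter) is estimated to be small and downward, close to the usual scatter, with a real chance that the assay reports no number at all.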

Compound 3, largest response reached (Emax), in percent of the reference or control that the assay uses: 9.8%
Estimate against measurement, compound 3: 10.2 percentage points above, and the stated range covers the measured number.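

In this assay, among these compounds, methyl in place of hydrogen on the amine nitrogen of the five-membered ring gives a number 19.2 percentage points lower from compound 2 to compound 3 (beyond the scatter), the first step that can be read between two measured compounds. It shows that this nitrogen is sensitive to change: a single added carbon lowers the maximal response by more than the usual scatter, although compound 3 still gives a measurable 9.8%. No measurement shown explains the drop, so the step describes what happens without revealing its cause.

A single pair cannot show whether the response keeps falling as the group on this nitrogen grows, as it might with an ethyl group or a longer chain such as propyl, or how a carbonyl-bearing group such as acetyl would behave there. It also leaves open whether the same methyl step would lower the response on a different core, and how much of each compound is needed to reach its maximal response.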